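Benzyl for phenyl on two cores, cytotoxicity read-out

The source may hold more compounds than are shown below. What is called first, only, known or untested is meant among the compounds shown, and "the series" means these compounds.

Measured compounds:
compound 1 `COC(=O)c1c[nH]c2ccc(OCCc3ccccc3)cc2c1=O`, 2200 nM
compound 2 `COC(=O)c1c[nH]c2ccc(OCCCc3ccccc3)cc2c1=O`, 17100 nM
compound 3 `COC(=O)c1c[nH]c2cc(OCc3ccccc3)ccc2c1=O`, 18900 nM

In an ADME assay on J774 cells (Mus musculus) for cytotoxicity (on this read-out lower numbers stand for an effect already at smaller amounts and higher numbers for an effect only at larger amounts of compound), compound 1 gives 2200 nM. Compound 2 differs from it by benzyl in place of phenyl on a saturated chain carbon, two bonds along the chain from an oxygen on an aromatic ring; in this assay compound 2 gives 17100 nM, which is a 7.8-fold higher number from compound 1 to compound 2 (0.89 log units; beyond the scatter). Compound 3 gives 18900 nM in this assay; how its core differs from the core of compound 1 is not broken down here, and its value and that of compound 2 lie within the scatter of each other.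

Compound 4 `COC(=O)c1c[nH]c2cc(OCCc3ccccc3)ccc2c1=O` is not yet measured. It differs from compound 3 by benzyl in place of phenyl on a saturated chain carbon bound to an oxygen on an aromatic ring. This is the same kind of change as from compound 1 to compound 2, but the place is not the same: there the new group sat on a saturated chain carbon two bonds along the chain from an oxygen on an aromatic ring, here on a saturated chain carbon bound to an oxygen on an aromatic ring.

For compound 4 a higher number than that of compound 3 is expected in this assay, a step estimated at a 2.6-fold higher number from compound 3 to compound 4 (0.42 log units; beyond the scatter). It is taken smaller than the measured step because a 7.8-fold higher number from compound 1 to compound 2 (0.89 log units; beyond the scatter) starts from compound 1 at 2200 nM, whereas compound 3 starts from 18900 nM. Compound 4 is estimated at 50000 nM, between 15000 nM and 200000 nM.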

Compound 4, half-maximal effective concentration: 17200 nM
Beside the measured number, compound 4's estimate is 2.9-fold (0.46 log units) above it; the measured number falls inside the stated range.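

In this assay, the change from phenyl to benzyl on the core of compound 3 gives a 1.1-fold lower number from compound 3 to compound 4 (0.04 log units; within the scatter), so no step beyond the scatter can be read on this core. Set beside the same change on the core of compound 1, the step does not carry over from one core to the other: the same change on two cores in this assay, a 7.8-fold higher number (0.89 log units; beyond the scatter) from compound 1 to compound 2 and a 1.1-fold lower number (0.04 log units; within the scatter) from compound 3 to compound 4, 8.5-fold (0.93 log units) apart, beyond the scatter of two such steps This rests on a single pair per core and on one read-out; it does not show which feature of the two cores goes with the gap, nor does it give a rule for any further core in the series.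

Open, going by these compounds, is how a longer chain on the core of compound 3 would read, and whether a carboxylic acid in place of the methyl ester would leave the gap between the two cores as it stands. Also open, on these data alone, is whether an amine in place of the phenyl ring would read alike on both cores.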